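This account rests on a few compounds, and the source may have more. Where it says the series, first, only, none or still open, it means among the compounds named here.

Measured so far:
compound 1, `C=CCn1c(=O)n(CCCC)c2nc(N)nc(O)c21`, 21%
compound 2, `N#Cc1cccc(Cn2c(=O)n(C3OC(CO)[C@@H](O)[C@H]3O)c3nc(N)nc(O)c32)c1`, 11%

Both compounds were measured in a functional assay on YAC-1 cells (Mus musculus); a higher number here means a larger maximal response, a lower number a smaller maximal response. Compound 2 gives 11% there, and compound 1 gives 21%; the two values lie within the usual scatter of each other, so compound 2 is not set apart from compound 1 on these numbers. Among the measured compounds shown here, no step between measured compounds is available that would isolate a single change.

Compound 3, `NC(=O)Cn1c(=O)n(C2OC(CO)[C@@H](O)[C@H]2O)c2nc(N)nc(O)c21`, is the next compound to be measured in this assay. It differs from compound 2 by carbamoyl in place of 3-cyanophenyl on a saturated chain carbon bound to an aromatic nitrogen. The shared core and the sugar-like part on the other aromatic nitrogen are kept.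

For the measured compounds named here, with no comparable step in hand, the step from compound 2 to compound 3 is expected to stay within the scatter, in either direction: a number 3 percentage points higher from compound 2 to compound 3 (within the scatter) is the estimate. Compound 3 is therefore expected at 14%, with a range from 4% to 30%.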

Compound 3, largest response reached (reported as maximal response), in percent of the reference or control that the assay uses: 42%
Estimate against measurement, compound 3: 28 percentage points below; the whole stated range lies below it.
By their numbers in this assay, from the lowest: compounds 2 and 1 (each within the scatter of the next); then compound 3.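

Within this assay, replacing 3-cyanophenyl by carbamoyl on a saturated chain carbon bound to an aromatic nitrogen gives a number 31 percentage points higher from compound 2 to compound 3 (beyond the scatter), with the shared core and the sugar-like part kept. Among the compounds shown here, this is the first single change, and it shows that the maximal response depends on the group at this position, which the pair of compound 1 and compound 2, differing in more than one place, could not show. Nothing at hand accounts for the size of this step.

On these data alone, whether the step follows from losing the aromatic ring, losing the nitrile or gaining the amide stays open. A carboxylic acid, an amine or an unsubstituted benzyl at this position would help separate these, as would a longer chain carrying the carbamoyl.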